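This account rests on a few compounds, and the source may have more. Where it says the series, first, only, none or still open, it means among the compounds named here.

Compound 2 `CC(C)[C@H](NC(=O)COc1cccc2ccccc12)C(=O)N[C@@H](CC(=O)O)C(=O)COc1ccc([N+](=O)[O-])cc1` and compound 1 `CC(C)[C@H](NC(=O)COc1cccc2ccccc12)C(=O)N[C@@H](CC(=O)O)C(=O)COc1ccccc1C(F)(F)F` share one core and differ only in the aryl group on the oxygen on the saturated carbon. In a functional assay on Jurkat cells (Homo sapiens) (on this read-out higher numbers stand for weaker inhibition and lower numbers for stronger inhibition), compound 1 gives only a limit, > 100000 nM. In this assay compound 2 likewise gives only a limit, > 100000 nM. Among the measured compounds shown here, the single measured step, a step that the two limits leave unreadable from compound 1 to compound 2, is therefore unreadable, because both values sit at the limit of > 100000 nM in this assay, at which 2 of the 2 values shown sit. Compound 2 thus stands at the edge of what this read-out can report, and nothing in the numbers shown separates it from compound 1.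

Compound 3 `CC(C)[C@H](NC(=O)COc1cccc2ccccc12)C(=O)N[C@@H](CC(=O)O)C(=O)COc1c(F)ccc(F)c1F` is reached from compound 2 by 2,3,6-trifluorophenyl in place of 4-nitrophenyl on an oxygen on a saturated carbon. For the measured compounds named here, no measured step bears on this change: the only step in the set is the unreadable one just described, and it tells nothing about a fluorinated phenyl on that oxygen. The step of a number no higher from compound 2 to compound 3 (the limit leaves the size open) is expected to be small or absent, most likely ending again at a limit. Compound 3 is therefore expected to give about 100000 nM in this assay, within a range from 20000 nM to 300000 nM.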

Compound 3, half-maximal inhibitory concentration: 1200 nM
Beside the measured number, compound 3's estimate is 83-fold (1.92 log units) above it; measured number outside the range, below it.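

Compound 3 shows that the aryl group on the oxygen on a saturated carbon can decide whether this series registers at all in this assay, which the first two compounds, both stuck at a limit, could not show. Replacing 4-nitrophenyl with 2,3,6-trifluorophenyl gives an at least 83-fold lower number from compound 2 to compound 3 (1.92 log units; beyond the scatter), and replacing 2-(trifluoromethyl)phenyl with the same group gives an at least 83-fold lower number from compound 1 to compound 3 (1.92 log units; beyond the scatter), so the change from either of the two earlier aryl groups leads to the same measured compound. The full size of both steps remains unknown because each starts from a limit, not a number: the limit of > 100000 nM in this assay, at which 2 of the 3 values shown sit.

The compounds shown do not tell whether the gain needs all the fluorines of 2,3,6-trifluorophenyl, since a plain phenyl or a monofluorophenyl on that oxygen does not appear among them. They also leave open whether a chlorophenyl or a non-aromatic group such as cyclohexyl at this place would give a value like that of compound 3 or fall back to a limit.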